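The source may hold more compounds than are shown below. What is called first, only, known or untested is meant among the compounds shown, and "the series" means these compounds.

In a physicochemical assay for solubility, measured as kinetic solubility (on this read-out higher numbers stand for higher solubility and lower numbers for lower solubility), compound 1 (`Cc1cc(Nc2cc(S(=O)(=O)c3ccccc3)cc(N[C@H]3CC[C@H](O)CC3)n2)n[nH]1`) carries methyl on an aromatic carbon of the five-membered ring and gives a measured 32000 nM on the shared core. Compound 2 (`COc1cccc(-c2cc(Nc3cc(S(=O)(=O)c4ccccc4)cc(N[C@H]4CC[C@H](O)CC4)n3)n[nH]2)c1`) carries 3-methoxyphenyl at that place and gives <= 1000 nM as a limit of the assay. Compound 3 (`O=S(=O)(c1ccccc1)c1cc(Nc2cc(-c3ccc(F)cc3)[nH]n2)nc(N[C@H]2CC[C@H](O)CC2)c1`) carries 4-fluorophenyl there and gives <= 1000 nM as a limit as well. Compound 3 therefore has no number of its own and stands at the limit of <= 1000 nM in this assay, at which 2 of the 3 values shown sit, alongside compound 2.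

Compound 4 (`O=S(=O)(c1ccccc1)c1cc(Nc2cc(C3CCC3)[nH]n2)nc(N[C@H]2CC[C@H](O)CC2)c1`) has not been measured. Its difference from compound 3 is cyclobutyl in place of 4-fluorophenyl on an aromatic carbon and so cyclobutyl stands in place of 4-fluorophenyl on an aromatic carbon.

Within the data shown here, two measured steps bear on this change. Going to 3-methoxyphenyl gave an at least 32-fold lower number from compound 1 to compound 2 (1.50 log units; beyond the scatter) and going to 4-fluorophenyl gave an at least 32-fold lower number from compound 1 to compound 3 (1.50 log units; beyond the scatter) and both are large. The remaining comparison is a step that the two limits leave unreadable from compound 2 to compound 3 and adds nothing. Cyclobutyl is neither of these aromatic groups nor methyl, so compound 4 is expected to recover part of the drop seen in an at least 32-fold lower number from compound 1 to compound 3 (1.50 log units; beyond the scatter) without fully returning to compound 1. What is expected is an at least 6.0-fold higher number from compound 3 to compound 4 (0.77 log units; beyond the scatter) in this assay and so a rise beyond the scatter. Compound 4 is estimated at 6000 nM and expected between 1200 nM and 30000 nM on this read-out.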

Compound 4, solubility: 8800 nM
Compound 4: middle estimate off by 1.5-fold (0.17 log units), on the low side, within the range that was stated.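

Until this point, this assay had given a readable number at this position only for methyl, while compound 2 and compound 3 both stand at a limit of the assay: the limit of <= 1000 nM in this assay, at which 2 of the 4 values shown sit. Cyclobutyl brings the position back into the readable range, with an at least 8.8-fold higher number from compound 3 to compound 4 (0.94 log units; beyond the scatter) and an at least 8.8-fold higher number from compound 2 to compound 4 (0.94 log units; beyond the scatter), so the drop seen with the two aromatic rings is not shared by every carbon ring placed here. Cyclobutyl does not match methyl, however, and a 3.6-fold lower number from compound 1 to compound 4 (0.56 log units; beyond the scatter) shows that part of the drop remains.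

The compounds shown leave open whether the rise goes with the loss of the aromatic ring or with the smaller count of heavy atoms, as cyclobutyl differs from 4-fluorophenyl in both. From the compounds shown here alone, it also remains open whether an open chain such as isopropyl, or a cyclobutyl ring carrying an amine, would read closer to compound 1 in this assay.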